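Moving from a piperidine to a methylpyrrolidine

A few compounds are considered here, and "the series" means these few. Any claim that something is new, unique, unknown or untested is made for them only; others in the source may bear on it.

Compound 1 `CC1(CN)CCN(c2c(F)cc3c(=O)c(C(=O)O)cn(C4CC4)c3c2C(F)(F)F)C1`: 110 ug/mL
Compound 2 `NC1CCCN(c2c(F)cc3c(=O)c(C(=O)O)cn(C4CC4)c3c2C(F)(F)F)C1`: > 500 ug/mL (a limit)

In a functional assay on V79 cells (Cricetulus griseus) for cytotoxicity, read by colony formation (a higher number here means a weaker inhibitor, a lower number a stronger inhibitor), compound 1 gives 110 ug/mL. On these data alone, compound 2 gives only a limit, > 500 ug/mL, so its exact position is unknown.

Compound 3 `CC1(N)CCN(c2c(F)cc3c(=O)c(C(=O)O)cn(C4CC4)c3c2C(F)(F)F)C1` contains the same atoms as compound 2, joined differently: 3-amino-3-methylpyrrolidin-1-yl replaces 3-aminopiperidin-1-yl on an aromatic carbon (3-amino-3-methylpyrrolidin-1-yl in place of 3-aminopiperidin-1-yl on an aromatic carbon).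

Among the measured compounds shown here, one measured step bears on this change: an at least 4.5-fold higher number from compound 1 to compound 2 (0.65 log units; beyond the scatter). That step also replaces a group carrying a methyl on a five-membered non-aromatic ring with 3-aminopiperidin-1-yl. Compound 3 regains such a ring, so a lower number is expected in this assay, though this rests on a single step. The expected change is an at least 2.7-fold lower number from compound 2 to compound 3 (0.44 log units; beyond the scatter). For compound 3 the estimated value is 180 ug/mL, with an expected range of 60 ug/mL to 500 ug/mL.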

Compound 3, half-maximal inhibitory concentration: 110 ug/mL
Beside the measured number, compound 3's estimate is 1.6-fold (0.21 log units) above it; the range from low to high includes it.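

Joining the same atoms as a 3-amino-3-methylpyrrolidin-1-yl group rather than a 3-aminopiperidin-1-yl group gives an at least 4.5-fold lower number from compound 2 to compound 3 (0.65 log units; beyond the scatter) in this assay, so the arrangement of the amine-bearing ring matters at this position, even with no change in atom count. The figure for compound 2 is a limit, not a number: the limit of > 500 ug/mL in this assay, at which 1 of the 3 values shown sits. Replacing aminomethyl with amino on the saturated ring carbon gives no change at the digits printed from compound 1 to compound 3 (within the scatter), which suggests that, among these compounds, the length of that arm is not what separates compound 1 from compound 2.

The ring size and the methyl group change together between compound 2 and compound 3, so their separate contributions remain unresolved. A 3-aminopyrrolidin-1-yl group, which has the five-membered ring without the methyl, would help pull the two apart.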